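This account rests on a few compounds, and the source may have more. Where it says the series, first, only, none or still open, it means among the compounds named here.

Measured compounds:
Compound 1, `CC(C(=O)N1CCN(c2ccc(Cl)cc2)CC1)N1C(=O)CCC1=O`, gives 0%.
Compound 2, `CCC(C(=O)N1CCN(c2cccc(C)c2)CC1)N1C(=O)CCC1=O`, gives 0%.

Both measured compounds were tested in a functional assay on the whole organism (strain Swiss) with Mus musculus as the target, in the maximal electroshock model, with a stated time of 2 h, at a dose of 300 mg/kg by the intraperitoneal route; a lower number here means a weaker effect, a higher number a stronger effect of the compound at the dose given. In this assay compound 1 gives 0%, and compound 2 gives 0%. Compound 2 therefore stands level with compound 1 at the digits reported; the two values lie within the usual scatter of each other, and nothing separates them.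

Compound 3, `Cc1cccc(N2CCN(C(=O)C(C)N3C(=O)CCC3=O)CC2)c1`, has not yet been measured. It differs from compound 2 in one place: hydrogen in place of methyl on a saturated chain carbon, two bonds along the chain from an amide-type nitrogen in a ring and a carbonyl carbon. Among the measured compounds shown here, no step between measured compounds covers this difference. Compound 1 already carries the shorter chain that compound 3 will carry, on a different aryl group, and compound 1 shows 0%, so no effect beyond the scatter is expected from the change. Compound 3 is expected to give 0%, with a range from 0% to 10%. The step this estimate means, no change at the digits printed from compound 2 to compound 3 (within the scatter), is expected to be none beyond the scatter, because compound 2 gives 0% and compound 1 gives 0%.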

Compound 3, a percentage reported as activity, at one dose (the size of the read-out at that dose, not a potency): 0%
Beside the measured number, compound 3's estimate shows no gap at the digits printed, within the range that was stated.
By their numbers in this assay, from the lowest: compounds 1, 2 and 3 (each within the scatter of the next).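

In this assay, among the compounds shown here, hydrogen in place of methyl on a saturated chain carbon, two bonds along the chain from an amide-type nitrogen in a ring and a carbonyl carbon, gives no change at the digits printed from compound 2 to compound 3 (within the scatter) and thus provides the first reading of this chain change with the aryl group held constant. Compounds 1 and 2 differed in both places, so neither change could be read alone; now 3-methylphenyl in place of 4-chlorophenyl on an amine nitrogen in a ring, with the chain held constant, gives no change at the digits printed from compound 1 to compound 3 (within the scatter) and shows no separation at that position either. No supporting evidence accompanies these readings to account for them.

With all three readings level at a single dose and time, the compounds shown leave open whether either position can influence the read-out in this assay under other conditions. Also open, on these data alone, is what a longer chain such as propyl at the saturated carbon would give, or an amine or a carboxylic acid in place of the 3-methylphenyl group.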